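The source may hold more compounds than are shown below. What is called first, only, known or untested is meant among the compounds shown, and "the series" means these compounds.

Compound 1 `COc1cc(C(=O)c2cn(-c3cccc(C)c3)cc2-c2ccccn2)cc(OC)c1OC` is the starting point; in a functional assay on MCF7 cells (Homo sapiens) for inhibition, with a stated time of 96 h (on this read-out higher numbers stand for weaker inhibition and lower numbers for stronger inhibition), compound 1 gives 140 nM. Compound 2 `COc1cc(C(=O)c2cn(-c3cccc(C)c3)cc2-c2cccnc2)cc(OC)c1OC` differs from it by pyridin-3-yl in place of pyridin-2-yl on an aromatic carbon, and in this assay compound 2 gives 52 nM, a step of a 2.7-fold lower number from compound 1 to compound 2 (0.43 log units; beyond the scatter). Compound 3 `COc1cc(C(=O)c2cn(-c3ccc(C)cc3)cc2-c2ccccn2)cc(OC)c1OC` carries the change (4-methylphenyl in place of 3-methylphenyl on an aromatic nitrogen), and in this assay compound 3 gives 36 nM, a step of a 3.9-fold lower number from compound 1 to compound 3 (0.59 log units; beyond the scatter). Compound 4 `COc1cc(C(=O)c2cn(-c3ccc(C)cc3)cc2-c2cccnc2)cc(OC)c1OC` has not yet been measured; it differs from compound 3 by pyridin-3-yl in place of pyridin-2-yl on an aromatic carbon. This is the same kind of change as that made between the first two compounds, though not the same: there the ring atom two ring bonds away bears a 3-methylphenyl group, here a 4-methylphenyl group. Resting on a 2.7-fold lower number from compound 1 to compound 2 (0.43 log units; beyond the scatter), compound 4 is expected to show a 2.4-fold lower number from compound 3 to compound 4 (0.38 log units; beyond the scatter). Compound 4 is therefore estimated at 15 nM, likely between 6 nM and 40 nM.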

Compound 4, half-maximal inhibitory concentration: 19 nM
For compound 4 the middle estimate is 1.3-fold (0.10 log units) below the measured one; low and high end bracket the measured number.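

On the core of compound 3, pyridin-3-yl in place of pyridin-2-yl gives a 1.9-fold lower number from compound 3 to compound 4 (0.28 log units; within the scatter), and this step agrees with its earlier counterpart: the same change on two cores in this assay, a 2.7-fold lower number (0.43 log units; beyond the scatter) from compound 1 to compound 2 and a 1.9-fold lower number (0.28 log units; within the scatter) from compound 3 to compound 4, 1.4-fold (0.15 log units) apart, within the scatter of two such steps

On the core of compound 2, 4-methylphenyl in place of 3-methylphenyl gives a 2.7-fold lower number from compound 2 to compound 4 (0.44 log units; beyond the scatter), and this change also carries over: the same change on two cores in this assay, a 3.9-fold lower number (0.59 log units; beyond the scatter) from compound 1 to compound 3 and a 2.7-fold lower number (0.44 log units; beyond the scatter) from compound 2 to compound 4, 1.4-fold (0.15 log units) apart, within the scatter of two such steps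

Each change therefore keeps a similar size across these two cores, but two instances apiece do not show that it would do so on any other core, nor do they explain why the numbers shift.

The compounds shown leave open how a pyridin-4-yl group would compare with the two pyridine isomers. They also leave open what a methoxy or chloro group on that phenyl ring would give in place of methyl.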